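Bromine on the Phenyl Ring of Compound 3

This account rests on a few compounds, and the source may have more. Where it says the series, first, only, none or still open, it means among the compounds named here.

Of the compounds shown here, three have been measured in a functional assay on HeLa cells for agonist activity at 5-hydroxytryptamine receptor 6 (Homo sapiens), read by cAMP accumulation and immunoassay; a lower number here means that less compound is needed, a higher number that more compound is needed for the effect. Compound 1, `O=S(=O)(c1ccc(F)cc1)c1cn(C2CCNC2)c2ncccc12`, gives 1650 nM. Compound 2, `CN1CCC(n2cc(S(=O)(=O)c3cccc(F)c3)c3cccnc32)C1`, gives 231 nM. Compound 3, `O=S(=O)(c1ccccc1)c1cn(C2CCCNC2)c2ncccc12`, gives 47 nM, the lowest of the three numbers: compound 2 sits a good way above it, and compound 1 further still, both beyond the usual scatter. Compound 1 and compound 2 each differ from compound 3 in more than one place, so none of these gaps can be tied to a single change.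

Compound 4, `O=S(=O)(c1cccc(Br)c1)c1cn(C2CCCNC2)c2ncccc12`, differs from compound 3 in one place: bromo in place of hydrogen on an aromatic carbon, that is, phenyl becoming 3-bromophenyl, with the bromine meta to a large group. Among the measured compounds shown here, no measured pair shows this same change on its own, so there is nothing to set its size from. The expectation is that the step from compound 3 to compound 4 stays small, a 1.1-fold higher number from compound 3 to compound 4 (0.03 log units; within the scatter), no further than the scatter reaches in either direction. Compound 4 is therefore estimated at 50 nM, with a range from 15 nM to 170 nM.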

Compound 4, half-maximal effective concentration: 72 nM
Compound 4: the middle estimate sits 1.4-fold (0.16 log units) below what was measured; measured number inside the range.
By their numbers in this assay, from the lowest: compounds 3 and 4 (each within the scatter of the next); then compound 2; then compound 1.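

Bromo in place of hydrogen on this aromatic carbon comes with a 1.5-fold higher number from compound 3 to compound 4 (0.19 log units; within the scatter) in this assay and so leaves the two compounds indistinguishable. Among the compounds shown here, this is the first comparison in the set that isolates a single change, and it shows that the phenyl ring of compound 3 can carry a bromine meta to a large group with no difference beyond the scatter. No supporting measurement bears on this result, so the data offer no explanation for it.

Going by these compounds, whether the same place would accept a group larger or very different from bromine, such as a methoxy group, an amine or a carboxylic acid, remains open. A single step also cannot show whether bromo on another carbon of the ring, or on the ring of a compound with a different amine portion, would give a similarly small step.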